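A Heteroaryl Swap on the Ring Amine Nitrogen

The source may report more compounds than this note shows. Statements on the series, on what has been measured and on what is new or still open speak of the compounds shown alone.

For the measured compounds named here, compound 2 `CCc1cnc(N2CCC(CCCNc3ccc4c(c3)OCC4=O)CC2)nc1` gives 117 nM in a functional assay on CHO-K1 cells for agonist activity at Glucose-dependent insulinotropic receptor (Homo sapiens), read by HTRF and cAMP accumulation, with a stated time of 30 min (a lower number here means that less compound is needed, a higher number that more compound is needed for the effect), the lowest of the two numbers known so far; compound 1 `CC(C)(C)OC(=O)N1CCC(CCCNc2ccc3c(c2)NNS3(=O)=O)CC1` gives 268 nM in this assay, a gap beyond the scatter. Compound 3 `CC(C)c1nc(N2CCC(CCCNc3ccc4c(c3)OCC4=O)CC2)no1` differs from compound 2 in one place: 5-isopropyl-1,2,4-oxadiazol-3-yl in place of 5-ethylpyrimidin-2-yl on an amine nitrogen in a ring. Going by the values given here, no measured pair shows this change, so its effect is unknown. The author expects the step from compound 2 to compound 3 in this assay to be a 1.3-fold higher number from compound 2 to compound 3 (0.11 log units; within the scatter), not beyond the scatter and without a clear direction. The estimate for compound 3 in this assay is 150 nM, in a range from 45 nM to 500 nM.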

Compound 3, half-maximal effective concentration: 161 nM
Estimate against measurement, compound 3: 1.1-fold (0.03 log units) below, within the range that was stated.
By their numbers in this assay, from the lowest: compounds 2, 3 and 1 (each within the scatter of the next, the first and the last beyond it).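

In this assay, for the compounds shown here, the swap of 5-ethylpyrimidin-2-yl for 5-isopropyl-1,2,4-oxadiazol-3-yl gives a 1.4-fold higher number from compound 2 to compound 3 (0.14 log units; within the scatter) and is the first step read at this amine nitrogen in a ring. Within these two compounds, a five-membered aromatic ring with 3 hetero atoms serves here as well as a six-membered one with 2 hetero atoms. Nothing measured here accounts for this result.

What the compounds leave open is whether an amide or a simple alkyl chain on this nitrogen would hold the number, and whether the isopropyl group itself matters, as against a methyl or a tert-butyl group on the oxadiazole.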